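Cyano for Bromo on a Benzyl Triazole Ether

A few compounds are considered here, and "the series" means these few. Any claim that something is new, unique, unknown or untested is made for them only; others in the source may bear on it.

Of the compounds shown here, three sharing one core have been tested in a functional assay on SGC-7901 cells (Homo sapiens) for cytotoxicity, read by MTT assay, with a stated time of 48 h; a lower number here means a stronger inhibitor, a higher number a weaker inhibitor. Compound 1, `Cc1cccc(Cn2cc(COc3ccc4c(=O)ccoc4c3)nn2)c1`, carries a methyl on its benzyl ring, and in this assay compound 1 gives > 100000 nM, which is a limit of the assay rather than a number. Compound 2, `O=c1ccoc2cc(OCc3cn(Cc4cccc(F)c4)nn3)ccc12`, carries a fluoro instead, and in this assay compound 2 gives > 100000 nM, again a limit. Compound 3, `O=c1ccoc2cc(OCc3cn(Cc4ccc(Br)cc4)nn3)ccc12`, carries a bromo, and in this assay compound 3 gives > 100000 nM, also a limit. For the measured compounds named here, compound 3 therefore stands where every value so far stands, at the limit of > 100000 nM in this assay, at which 3 of the 3 values shown sit.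

The next compound, compound 4, `N#Cc1ccc(Cn2cc(COc3ccc4c(=O)ccoc4c3)nn2)cc1`, differs from compound 3 by cyano in place of bromo on an aromatic carbon. The measured steps that bear on a change at this benzyl ring are a step that the two limits leave unreadable from compound 1 to compound 3 and a step that the two limits leave unreadable from compound 2 to compound 3, alongside a step that the two limits leave unreadable from compound 1 to compound 2; all three are unreadable because each end sits at the limit of > 100000 nM in this assay, at which 3 of the 3 values shown sit. No step shown has yet produced a number in this assay, so the structural change gives no reason to expect a readable gain.

The expected step is a step that the limit leaves unreadable from compound 3 to compound 4, most likely again unreadable. Compound 4 is therefore estimated to give 150000 nM, with a range from 30000 nM to 600000 nM.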

Compound 4, half-maximal inhibitory concentration: > 100000 nM
Compound 4: no number, only a limit; the forecaster's own chance of this, stated with the estimate: 80%; the middle value lies beyond the limit too.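

In this assay compound 4 gives > 100000 nM, which is a limit of the assay and not a number. Its steps from compound 1, compound 2 and compound 3 cannot be read, because all four compounds end at the same limit: the limit of > 100000 nM in this assay, at which 4 of the 4 values shown sit.

The compounds shown leave open how strongly any of them acts on these cells, and whether changing the group on the benzyl ring alters that at all.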